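A few compounds are considered here, and "the series" means these few. Any claim that something is new, unique, unknown or untested is made for them only; others in the source may bear on it.

Measured in an ADME assay on Vero cells (Chlorocebus sabaeus) for cytotoxicity, read by MTT assay, with a stated time of 72 h; a higher number here means that more compound is tolerated, a lower number that less compound is tolerated:
- compound 1 `COc1c(N2CCN(CC(C)=O)C(C)C2)c(F)cc2c(=O)c(C(=O)O)cn(C3CC3)c12`: 500 ug/mL
- compound 2 `CCO/N=C(\C)CN1CCN(c2c(F)cc3c(=O)c(C(=O)O)cn(C4CC4)c3c2OC)CC1C`: 31.3 ug/mL
- compound 3 `COc1c(N2CCN(C/C(C)=N/NC(N)=O)C(C)C2)c(F)cc2c(=O)c(C(=O)O)cn(C3CC3)c12`: 500 ug/mL

Compound 3 gives 500 ug/mL, level with compound 1, and the two share the highest of the three values. Compound 2 stands well below both.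

The next compound is compound 4 `COc1c(N2CCN(C/C(C)=N/Nc3ccccc3)C(C)C2)c(F)cc2c(=O)c(C(=O)O)cn(C3CC3)c12`, with phenyl in place of carbamoyl on an amine nitrogen. In words, this is phenyl in place of carbamoyl on an amine nitrogen, or ureido to anilino.

Going by the values given here, no measured step makes this exact change. The nearest is a 16-fold higher number from compound 2 to compound 3 (1.20 log units; beyond the scatter), with ureido in place of ethoxy on a double-bonded nitrogen, and it is large. Read alongside it, a 16-fold lower number from compound 1 to compound 2 (1.20 log units; beyond the scatter) is equally large, whereas no change at the digits printed from compound 1 to compound 3 (within the scatter) stays within the scatter. Compound 2 is thus the only one of the three with a clearly lower number, and like compound 4 it has no ureido. Compound 1 also has no ureido, yet it is level with compound 3, so the evidence is thin and goes both ways.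

A lower number in this assay is expected, probably a step beyond the scatter. The expected step is an 8.3-fold lower number from compound 3 to compound 4 (0.92 log units; beyond the scatter). The estimate for compound 4 is 60 ug/mL, with an expected range from 15 ug/mL to 250 ug/mL.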

Compound 4, half-maximal cytotoxic concentration: 11.1 ug/mL
Compound 4: middle estimate off by 5.4-fold (0.73 log units), on the high side, and the stated range ends above it.
By their numbers in this assay, from the lowest: compound 4; then compound 2; then compounds 1 and 3 (each within the scatter of the next).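

Phenyl in place of carbamoyl on an amine nitrogen gives a 45-fold lower number from compound 3 to compound 4 (1.65 log units; beyond the scatter) in this assay, so a change at this one place in the side chain can move the number further than the ethoxy group did. Exchanging ethoxy for anilino gives a 2.8-fold lower number from compound 2 to compound 4 (0.45 log units; beyond the scatter), a modest step that places the anilino group below ethoxy, while the anilino side chain in place of the ketone side chain gives a 45-fold lower number from compound 1 to compound 4 (1.65 log units; beyond the scatter). Of the three groups on the double-bonded nitrogen, ethoxy and anilino both sit clearly below the ketone, and ureido is the exception, level with it at the digits printed. No measurement in hand accounts for the drop on going to anilino.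

From the compounds shown here alone, whether the low number belongs to the phenyl ring itself or simply follows from the loss of the ureido remains open, and a benzyl group, a pyridyl ring or a methyl group on that amine nitrogen would help separate the two. Also open, going by these compounds, is whether a plain hydroxyl on the double-bonded nitrogen stays level with ureido or falls towards ethoxy.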